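The compounds below may be only part of what the source reports. "The series", "measured", "known", "first", "only" and "open" are said of these compounds alone.

Compound 1 `COc1cc(/C=C/C(=O)c2cccc(-n3cc(-c4ccc(Cl)cc4)[nH]c3=O)c2)cc(OC)c1OC` is the weakest of the three measured compounds in a functional assay on Malme-3M cells (Homo sapiens) for inhibition (on this read-out lower numbers stand for stronger inhibition of growth and higher numbers for weaker inhibition of growth), where compound 1 gives 18100 nM. Compound 2 `COc1cc(/C=C/C(=O)c2cccc(-n3cc(-c4ccccc4)[nH]c3=O)c2)ccc1O` gives 2670 nM in this assay, and compound 3 `COc1ccc(-c2cn(-c3cccc(C(=O)/C=C/c4ccc(O)c(OC)c4)c3)c(=O)[nH]2)cc1` gives 4420 nM. Compound 4 `COc1cc(/C=C/C(=O)c2cccc(-n3cc(-c4cc(OC)c(OC)c(OC)c4)[nH]c3=O)c2)cc(OC)c1OC` differs from compound 1 in a single place: 3,4,5-trimethoxyphenyl in place of 4-chlorophenyl on an aromatic carbon. Going by the values given here, the one measured step that touches the same aryl ring, a methoxy in place of hydrogen on an aromatic carbon, is a 1.7-fold higher number from compound 2 to compound 3 (0.22 log units; within the scatter). On that basis the exchange of a chlorine for three methoxy groups is expected to move this assay little, with a 1.2-fold lower number from compound 1 to compound 4 (0.08 log units; within the scatter) as the anticipated step. Compound 4 is therefore estimated at 15000 nM, within a range of 5000 nM to 45000 nM.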

Compound 4, concentration for 50% growth inhibition: 1800 nM
Compound 4: the middle estimate sits 8.3-fold (0.92 log units) above what was measured; the whole stated range lies above it.
By their numbers in this assay, from the lowest: compounds 4, 2 and 3 (each within the scatter of the next, the first and the last beyond it); then compound 1.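

Exchanging 4-chlorophenyl for 3,4,5-trimethoxyphenyl on this aromatic carbon gives in this assay a 10-fold lower number from compound 1 to compound 4 (1.00 log units; beyond the scatter) and thus a step beyond the scatter. The earlier compounds showed only a single methoxy in place of hydrogen, with a 1.7-fold higher number from compound 2 to compound 3 (0.22 log units; within the scatter) within the scatter, so this position had not yet shown that the aryl group can move the read-out this far. Nothing available explains this step.

The compounds shown leave open which of the three methoxy groups, or whether the loss of chlorine, carries the step. On these data alone, how a dimethylamino group or a carboxylic acid on this aryl ring would read also remains open.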